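Benzofuran-2-yl in place of iodo on the shared core

A few compounds are considered here, and "the series" means these few. Any claim that something is new, unique, unknown or untested is made for them only; others in the source may bear on it.

Compound 3 `COc1ncnc2c1c(I)cn2[C@@H]1O[C@H](CO)[C@@H](O)[C@H]1O` stands at the edge of the measured range: in a functional assay on A549 cells (Homo sapiens), read by MTT assay, with a stated time of 72 h (a lower number here means a stronger inhibitor, a higher number a weaker inhibitor), compound 3 gives > 20000 nM, which is a limit and not a number. Compound 1 `COc1ncnc2c1c(-c1cccs1)cn2[C@@H]1O[C@H](CO)[C@@H](O)[C@H]1O` gives 4850 nM in this assay. Compound 2 `COc1ncnc2c1c(-c1ccccc1)cn2[C@@H]1O[C@H](CO)[C@@H](O)[C@H]1O` gives > 20000 nM, again a limit. Two values therefore sit at the limit of > 20000 nM in this assay, at which 2 of the 3 values shown sit. The change to compound 4 `COc1ncnc2c1c(-c1cc3ccccc3o1)cn2[C@@H]1O[C@H](CO)[C@@H](O)[C@H]1O` is 1-benzofuran-2-yl in place of iodo on an aromatic carbon. Within the data shown here, the steps that bear on it are an at least 4.1-fold higher number from compound 1 to compound 3 (0.61 log units; beyond the scatter) and an at least 4.1-fold higher number from compound 1 to compound 2 (0.61 log units; beyond the scatter), while a step that the two limits leave unreadable from compound 2 to compound 3. Thiophen-2-yl is the only group here that yields a number. For 1-benzofuran-2-yl an outcome between these cases is expected, giving an at least 2.5-fold lower number from compound 3 to compound 4 (0.39 log units; beyond the scatter). Compound 4 is estimated at 8000 nM, within 2500 nM to 20000 nM.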

Compound 4, half-maximal inhibitory concentration: 17700 nM
Compound 4: the middle estimate sits 2.2-fold (0.34 log units) below what was measured, and the stated range covers the measured number.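

In this assay, 1-benzofuran-2-yl is the second group at this position to give a number rather than a limit, but thiophen-2-yl remains the better group, with a 3.6-fold higher number from compound 1 to compound 4 (0.56 log units; beyond the scatter). Against iodo the reading is an at least 1.1-fold lower number from compound 3 to compound 4 (0.05 log units; that floor lies within the scatter), and against phenyl it is an at least 1.1-fold lower number from compound 2 to compound 4 (0.05 log units; that floor lies within the scatter). Both are floors within the scatter, so no gain over either group is established: the limit of > 20000 nM in this assay, at which 2 of the 4 values shown sit.

The compounds shown leave open how furan-2-yl or thiophen-3-yl would read at this position. Also open, on these data alone, is whether an amine or a carboxylic acid on the thiophen-2-yl ring would keep the activity of compound 1.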